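The source may report more compounds than this note shows. Statements on the series, on what has been measured and on what is new or still open speak of the compounds shown alone.

Compound 1 `CCOC(=O)NC(=O)NC1=CS(=O)(=O)O[C@@]12[C@@H](CO[Si](C)(C)C(C)(C)C)O[C@@H](n1cc(C)c(=O)n(C)c1=O)[C@@H]2O[Si](C)(C)C(C)(C)C` gives 16000 nM in a functional assay on HEL cells (Homo sapiens) for cytotoxicity, read by microscopy; on this read-out higher numbers stand for lower toxicity in this test and lower numbers for higher toxicity in this test.
Compound 2 `Cc1cn([C@@H]2O[C@H](CO[Si](C)(C)C(C)(C)C)[C@@]3(OS(=O)(=O)C=C3NCCC(N)=O)[C@H]2O[Si](C)(C)C(C)(C)C)c(=O)n(C)c1=O` gives >= 80000 nM in this assay; this is a limit of the assay, not a measured number.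
Compound 3 `Cc1cn([C@@H]2O[C@@H]3COC(=O)[C@]3(OS(C)(=O)=O)[C@H]2O)c(=O)[nH]c1=O` gives >= 400000 nM in this assay; this also is a limit of the assay.

Compound 2 thus stands at the less severe of the two limits, namely (the limit of >= 80000 nM in this assay, at which 1 of the 3 values shown sits). Compound 3 sits at the other limit, (the limit of >= 400000 nM in this assay, at which 1 of the 3 values shown sits). Compound 1 is the only one of the three with a number rather than a limit.

The unmeasured compound 4 `Cc1cn([C@@H]2O[C@H](CO[Si](C)(C)C(C)(C)C)[C@@]3(OS(=O)(=O)C=C3NCC(=O)C(N)=O)[C@H]2O[Si](C)(C)C(C)(C)C)c(=O)n(C)c1=O` differs from compound 2 in one place: carbamoylcarbonyl in place of carbamoylmethyl on a saturated chain carbon bound to an amine nitrogen. Among the compounds with values here, the only step measured so far, an at least 5.0-fold higher number from compound 1 to compound 2 (0.69 log units; beyond the scatter), concerns a different exchange on the amine nitrogen, so it does not speak to this change. Within the data shown here, with no measured step bearing on it, the expectation is a step of about a number no higher from compound 2 to compound 4 (the limit leaves the size open), that is, none beyond the scatter. Compound 4 is therefore estimated at 80000 nM, with a range from 30000 nM to 200000 nM, and a result that is again only a limit is expected to be likely.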

Compound 4, minimum cytotoxic concentration: >= 16000 nM
Compound 4: only a limit was reported; the forecaster's own chance of this, stated with the estimate: 70%; the middle value lies beyond the limit too.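

In this assay compound 4 gives only a limit of the assay, not a number: the limit of >= 16000 nM in this assay, at which 1 of the 4 values shown sits.

Compound 2 also has only a limit, >= 80000 nM. The step from compound 2 to compound 4 therefore cannot be read, so the exchange of carbamoylmethyl for carbamoylcarbonyl has no readable size or direction, and a second chain on this amine nitrogen ends in a limit. With (carbamoylcarbonyl)methyl in place of (ethoxycarbonyl)carbamoyl on an amine nitrogen, the data show a number no lower from compound 1 to compound 4 (the limit leaves the size open).

Compound 1 is the only one of these compounds on this amine nitrogen with a measured number, so the compounds shown leave open how far the chain changes the read-out. Also open, going by these compounds, is how a carboxylic acid or an amine at the end of this chain, or a longer chain, would read in this assay.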